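The source may hold more compounds than are shown below. What is called first, only, known or untested is meant among the compounds shown, and "the series" means these compounds.

Within the data shown here, in an ADME assay on HCT-116 cells (Homo sapiens) for antiproliferative activity (on this read-out lower numbers stand for stronger inhibition and higher numbers for weaker inhibition), compound 1 `CCc1ccc(OC)c(COc2ccc(Cl)c(C)c2)c1` gives 43000 nM, the only actual number so far. Compound 2 `COc1ccc(C(N)=O)cc1COc1ccc(Cl)cc1` gives > 50000 nM, which is a limit of the assay and not a number. Among the measured compounds shown here, no step between measured compounds is available, so the data do not yet show how a single change moves this read-out. Compound 3 `COc1ccc(C#N)cc1COc1ccc(Cl)c(C)c1` keeps the core of compound 1 but carries cyano in place of ethyl on an aromatic carbon, meta to a large group and para to a methoxy group: cyano in place of ethyl on an aromatic carbon. Starting from compound 1 at 43000 nM, a step no larger than the usual scatter is expected in this assay, in neither direction. The expected change is a 1.1-fold lower number from compound 1 to compound 3 (0.03 log units; within the scatter). For compound 3 the estimate is 40000 nM, with an expected range from 15000 nM to 60000 nM.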

Compound 3, half-maximal inhibitory concentration: > 50000 nM
Compound 3 ended at the assay's limit (the forecaster's own chance of this, stated with the estimate: 40%); middle value at least 1.2-fold (0.09 log units) away from the limit.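

Cyano in place of ethyl on this aromatic carbon, meta to a large group and para to a methoxy group, gives the first step that can be read in this assay: an at least 1.1-fold higher number from compound 1 to compound 3 (0.06 log units; that floor lies within the scatter). From the compounds shown here alone, compound 3 stands at > 50000 nM, which is a limit of the assay and not a number, so the step is only a floor and its true size remains unknown. The result gives no sign of stronger inhibition with cyano than with ethyl at this position, and little of the read-out's range is left above compound 1: the limit of > 50000 nM in this assay, at which 2 of the 3 values shown sit.

Going by these compounds, how far compound 3 actually lies from compound 1 stays open. On these data alone, it is also open whether an amine, a carboxylic acid or a longer chain such as propyl at this position would move the number beyond the scatter.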